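The source may report more compounds than this note shows. Statements on the series, on what has been measured and on what is new or still open speak of the compounds shown alone.

Measured in a functional assay on SW480 cells (Homo sapiens) for inhibition, read by luminescence and resazurin assay, with a stated time of 3 days; a higher number here means a weaker inhibitor, a lower number a stronger inhibitor:

compound 1 `CNc1nc(NCc2ccc(NS(=O)(=O)c3ccc(F)cc3)cc2)c2ccccc2n1`: 4800 nM
compound 2 `CCCNc1nc(NCc2ccc(C(=O)N3CCC(C(=O)NCc4ccc(F)cc4)CC3)cc2)c2cc(C)ccc2n1`: 5200 nM
compound 3 `CCCNc1nc(NCc2ccc(C(=O)N3CCC(C(=O)NCc4ccc(F)cc4)CC3)cc2)c2ccccc2n1`: 5700 nM

Compound 2 stands in the middle of the three numbers, but its neighbours are within the scatter on both sides: the values of compound 1 and compound 2 lie within the scatter of one another, and the one change shown between measured compounds, hydrogen in place of methyl on an aromatic carbon, gives a 1.1-fold higher number from compound 2 to compound 3 (0.04 log units; within the scatter), which is no real movement.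

Compound 4 `Cc1ccc2nc(N(C)C)nc(NCc3ccc(C(=O)N4CCC(C(=O)NCc5ccc(F)cc5)CC4)cc3)c2c1` differs from compound 2 by dimethylamino in place of propylamino on an aromatic carbon. Within the data shown here, no measured step touches the amino group at this place; the only measured step, a 1.1-fold higher number from compound 2 to compound 3 (0.04 log units; within the scatter), concerns the ring methyl and does not bear on the exchange of propylamino for dimethylamino. The three measured compounds, which differ widely elsewhere, all sit within the scatter of each other, so nothing here points to a change in this assay. The expectation is therefore no step beyond the scatter, no change at the digits printed from compound 2 to compound 4 (within the scatter). Compound 4 is expected at 5200 nM, in the range 2500 nM to 11000 nM.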

Compound 4, half-maximal inhibitory concentration: 5600 nM
Compound 4: the middle estimate sits 1.1-fold (0.03 log units) below what was measured; the measured number falls inside the stated range.
By their numbers in this assay, from the lowest: compounds 1, 2, 4 and 3 (each within the scatter of the next).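

In this assay, among these compounds, dimethylamino in place of propylamino on the aromatic carbon between two ring nitrogen atoms gives a 1.1-fold higher number from compound 2 to compound 4 (0.03 log units; within the scatter) and is the first measured step at this position. Propylamino carries 1 hydrogen-bond donor and dimethylamino 0, and the shorter, fully substituted group leaves the number within the scatter, so in this pair neither that donor nor the change in chain shows any measurable effect. Nothing measured on hand accounts for this result.

Open, as far as these compounds go, is whether any group at this position can move the number beyond the scatter, for example an unsubstituted amino group, a morpholine ring or a longer chain such as hexylamino. Also open, from the compounds shown here alone, is whether the same exchange would stay within the scatter on a compound without the ring methyl, such as compound 3.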